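A few compounds are considered here, and "the series" means these few. Any claim that something is new, unique, unknown or untested is made for them only; others in the source may bear on it.

Compound 1, `O=C(NC(=S)N1CCc2c(OCCCCCOc3ccc(Cl)cc3)cccc21)Oc1ccccc1`, is the starting point. In an ADME assay on Huh-7 cells (Homo sapiens) for cytotoxicity (a lower number here means that less compound is tolerated, a higher number that more compound is tolerated), compound 1 is reported only as a limit, > 50000 nM. Two measured companions share its core and differ from it only at the carbonyl carbon. Compound 2, `O=C(NC(=S)N1CCc2c(OCCCCCOc3ccc(Cl)cc3)cccc21)c1cccc([N+](=O)[O-])c1`, gives 12100 nM in this assay, and compound 3, `O=C(NC(=S)N1CCc2c(OCCCCCOc3ccc(Cl)cc3)cccc21)c1ccc(F)cc1`, gives 31100 nM. Both steps, an at least 4.1-fold lower number from compound 1 to compound 2 (0.61 log units; beyond the scatter) and an at least 1.6-fold lower number from compound 1 to compound 3 (0.20 log units; that floor lies within the scatter), point downward, although the true size of each is open because compound 1 sits at the limit of > 50000 nM in this assay, at which 1 of the 3 values shown sits. Between the two measured analogues the step of a 2.6-fold higher number from compound 2 to compound 3 (0.41 log units; beyond the scatter) separates them.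

Compound 4, `CN(C)c1ccc(C(=O)NC(=S)N2CCc3c(OCCCCCOc4ccc(Cl)cc4)cccc32)cc1`, is not yet measured. It differs from compound 1 in one place: 4-(dimethylamino)phenyl in place of phenoxy on a carbonyl carbon. The two replacements at this carbonyl carbon that have been measured both lowered the number, so a similar, modest drop is expected for compound 4, an at least 2.0-fold lower number from compound 1 to compound 4 (0.30 log units; that floor lies within the scatter). Whether compound 4 will fall nearer to the first or the second of those companions cannot be told from three compounds. The value estimated for compound 4 is 25000 nM, with a range from 8000 nM to 50000 nM.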

Compound 4, half-maximal cytotoxic concentration: > 50000 nM
Compound 4 ended at the assay's limit; the forecaster's own chance of this, stated with the estimate: 25%; middle value at least 2.0-fold (0.30 log units) away from the limit.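

Compound 4 shows that an aromatic ring on this carbonyl carbon does not always lower the number in this assay, as the 3-nitrophenyl and 4-fluorophenyl groups seemed to suggest. Exchanging 3-nitrophenyl for 4-(dimethylamino)phenyl gives an at least 4.1-fold higher number from compound 2 to compound 4 (0.61 log units; beyond the scatter), while exchanging fluoro for dimethylamino on the aromatic ring gives an at least 1.6-fold higher number from compound 3 to compound 4 (0.20 log units; that floor lies within the scatter), and only the first of these lies clearly beyond the scatter. The step from phenoxy to 4-(dimethylamino)phenyl cannot be read, because both compounds end at the same limit: the limit of > 50000 nM in this assay, at which 2 of the 4 values shown sit.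

From the compounds shown here alone, how far the true values of compound 1 and compound 4 lie past that limit remains unknown. Going by these compounds, it also stays open whether a simple amine or a plain alkyl chain on this carbonyl carbon would reach the limit too.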